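Hydrazone aryl changes in the MKN-45 cytotoxicity series

The source may hold more compounds than are shown below. What is called first, only, known or untested is meant among the compounds shown, and "the series" means these compounds.

Compound 2 `COc1cc(/C=N/NC(=O)Nc2ccc(Oc3ccnc(-c4nncn4CCN(C)C)c3)c(F)c2)ccc1O` shows the highest number among the two measured compounds: in a functional assay on MKN-45 cells (Homo sapiens) for cytotoxicity, read by MTT assay, with a stated time of 72 h (on this read-out lower numbers stand for stronger inhibition and higher numbers for weaker inhibition), compound 2 gives 3780 nM. Its nearest neighbour is compound 1 `CN(C)CCn1cnnc1-c1cc(Oc2ccc(NC(=O)N/N=C/c3cccc(Cl)c3Cl)cc2F)ccn1`, for which this assay gives 51 nM; the step of a 74-fold higher number from compound 1 to compound 2 (1.87 log units; beyond the scatter) is the only measured one and carries the aryl change on the hydrazone carbon. Compound 3 `CN(C)CCn1cnnc1-c1cc(Oc2ccc(NC(=O)N/N=C/c3cccc(O)c3)cc2F)ccn1` is the next variation at that carbon: 3-hydroxyphenyl in place of 4-hydroxy-3-methoxyphenyl on a carbon with a double bond to nitrogen. For the measured compounds named here, the single measured step bears on it in that it shows how strongly this assay responds to the aryl group at this position, but it does not show the direction for a phenol without the methoxy group, so the expectation is uncertain. A moderate decrease in the number from compound 2 is expected, with a 2.5-fold lower number from compound 2 to compound 3 (0.40 log units; beyond the scatter) as the estimated step. For compound 3 in this assay the estimate is 1500 nM, within a range of 400 nM to 6000 nM.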

Compound 3, half-maximal inhibitory concentration: 1370 nM
The estimate for compound 3 lay 1.1-fold (0.04 log units) above the measured number, and the stated range covers the measured number.
By their numbers in this assay, from the lowest: compound 1; then compound 3; then compound 2.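

At the carbon with a double bond to nitrogen, 3-hydroxyphenyl in place of 4-hydroxy-3-methoxyphenyl gives a 2.8-fold lower number from compound 2 to compound 3 (0.44 log units; beyond the scatter) in this assay, so the assay separates these two hydroxy-bearing aryl groups, though by far less than the gap to the dichlorinated compound. The large gap is not confined to the 4-hydroxy-3-methoxyphenyl group: 3-hydroxyphenyl in place of 2,3-dichlorophenyl still gives a 27-fold higher number from compound 1 to compound 3 (1.43 log units; beyond the scatter), and compound 1 keeps the lowest number of the series. Nothing available accounts for either step.

The compounds shown leave open whether the low number of compound 1 depends on both chlorine atoms, and where an unsubstituted phenyl or a monochlorophenyl group would stand. They also leave open how a methoxyphenyl group without the hydroxy group would compare with 3-hydroxyphenyl.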